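The source may report more compounds than this note shows. Statements on the series, on what has been measured and on what is new or still open speak of the compounds shown alone.

Series notes. Compound 1 `COc1cc(C(C)C(=O)NCc2ccc(C(F)(F)F)nc2N2CCC(C)CC2)ccc1NS(C)(=O)=O` and compound 2 `CC1CCN(c2nc(C(F)(F)F)ccc2CNC(=O)C(C)c2ccc(NS(=O)(=O)C(C)C)c(F)c2)CC1` share a core and have both been measured in an assay on cells for antagonist activity at transient receptor potential cation channel subfamily V member 1 (Homo sapiens), read by FLIPR and calcium flux, with a stated time of 15 min; on this read-out higher numbers stand for weaker inhibition and lower numbers for stronger inhibition. In this assay compound 1 gives 0.8 nM, while compound 2 gives 8.7 nM. Of the two numbers in hand, compound 2 stands at the higher one; its nearest neighbour, compound 1, sits at a lower number, and that gap lies beyond the usual scatter of the read-out, so compound 2 is the weaker of the two on this read-out.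

Compound 3 `CC1CCN(c2nc(C(F)(F)F)ccc2CNC(=O)C(C)c2ccc(N(CC#N)S(C)(=O)=O)c(F)c2)CC1` is not yet measured in this assay. It differs from compound 2 in one place only: (cyanomethyl)(methylsulfonyl)amino in place of (isopropylsulfonyl)amino on an aromatic carbon. For the measured compounds named here, the change removes the hydrogen-bond donor carried by the (isopropylsulfonyl)amino group and brings in a nitrile on the (cyanomethyl)(methylsulfonyl)amino group; no measured pair in the set reports the effect of such a swap.

The expectation is a small step towards a higher number, a 2.3-fold higher number from compound 2 to compound 3 (0.36 log units; beyond the scatter), which could fall inside the scatter. Compound 3 is therefore estimated at 20 nM in this assay, in a range from 6 nM to 70 nM.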

Compound 3, inhibition constant: "not active" (no number reported)
The entry for compound 3 holds no number, so the estimate cannot be set against anything.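

For the compounds shown here, compound 3 is entered as "not active" in this assay with no number reported, so no step from compound 2 to compound 3 can be read. Nothing at hand bears on the cause of this result. The compounds shown leave open which part of the swap from (isopropylsulfonyl)amino to (cyanomethyl)(methylsulfonyl)amino governs this entry.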